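Para-substitution on the aryl ring of the aminothiophene series

The source may hold more compounds than are shown below. What is called first, only, known or untested is meant among the compounds shown, and "the series" means these compounds.

Measured compounds:
compound 1 `Nc1scc(-c2cccc(C(F)(F)F)c2)c1C(=O)c1ccccc1` with 83%
compound 2 `Nc1scc(-c2ccccc2)c1C(=O)c1ccccc1` with 49%

In a functional assay on CHO cells for agonist activity at adenosine receptor A1 (Homo sapiens), read by fluorescence and ERK phosphorylation, with stated times of 30 min and 1.5 h, tested at 3 uM (on this read-out lower numbers stand for a weaker effect and higher numbers for a stronger effect at the one concentration tested), compound 2 stands lowest of the two numbers measured; its nearest neighbour is compound 1, and the gap between them is beyond the scatter, as the step of a number 34 percentage points lower from compound 1 to compound 2 (beyond the scatter) shows. Compound 3 `Nc1scc(-c2ccc([N+](=O)[O-])cc2)c1C(=O)c1ccccc1` differs from compound 2 in one place: nitro in place of hydrogen on an aromatic carbon.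

Among the measured compounds shown here, only one measured step speaks to this change. The step of a number 34 percentage points lower from compound 1 to compound 2 (beyond the scatter) is large and shows that removing a substituent from the same aryl ring cost a good deal of effect. Whether a nitro group at the position given above restores it is not shown by any measured pair, so the expectation is uncertain. A moderate rise from compound 2 to compound 3 is expected, of size a number 16 percentage points higher from compound 2 to compound 3 (beyond the scatter).

For compound 3 the estimated value is 65%, within a range of 40% to 90%.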

Compound 3, a percentage reported as activity, at one concentration (the size of the read-out at that concentration, not a potency): 50%
Compound 3: middle estimate off by 15 percentage points, on the high side, within the range that was stated.
By their numbers in this assay, from the lowest: compounds 2 and 3 (each within the scatter of the next); then compound 1.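

In this assay, nitro on an aromatic carbon, para to a large group, gives the step of a number 1 percentage points higher from compound 2 to compound 3 (within the scatter), so at this place nitro cannot be told apart from hydrogen on this read-out. The earlier step of a number 34 percentage points lower from compound 1 to compound 2 (beyond the scatter) therefore does not extend to every group on this aryl ring: it describes trifluoromethyl at its own place, and compound 3 goes against any general reading that a group on the ring raises the read-out. The data at hand offer no explanation for this result.

As far as these compounds go, it remains open whether trifluoromethyl at the place held by nitro in compound 3 would give a read-out like that of compound 1. Also open, from the compounds shown here alone, is whether an amine or a carboxylic acid at this same place would stand apart from hydrogen.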